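This account rests on a few compounds, and the source may have more. Where it says the series, first, only, none or still open, it means among the compounds named here.

Compound 1 `O=Cc1ccc(-c2cn3ccnc3c(-c3ccc4ncn(C5CCCCC5)c4c3)n2)cc1`: 25.3%
Compound 2 `CC(=O)c1ccc(-c2cn3ccnc3c(-c3ccc4ncn(C5CCCCC5)c4c3)n2)cc1`: 10.4%

In a functional assay on NCI-H522 cells (Homo sapiens) for inhibition, read by sulforhodamine B assay, with a stated time of 48 h, tested at 10 uM (a higher number here means more inhibition at the concentration tested (going by the name of the read-out), a lower number less inhibition), compound 2 holds the lowest of the two numbers, sitting beyond the scatter under compound 1. For the measured compounds named here, the single measured step is a number 14.9 percentage points lower from compound 1 to compound 2 (beyond the scatter), and it changes only the carbonyl, not the aromatic ring that is exchanged next. Compound 3 `c1csc(-c2cn3ccnc3c(-c3ccc4ncn(C5CCCCC5)c4c3)n2)c1` differs from compound 2 by thiophen-2-yl in place of 4-acetylphenyl on an aromatic carbon. Going by the values given here, no measured step removes this ring, so the data give no direction for the change, and the expected step of a number 7.6 percentage points higher from compound 2 to compound 3 (within the scatter) is taken as small and uncertain. For compound 3 the estimate in this assay is 18%, with a range from 0% to 45%.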

Compound 3, a percentage reported as inhibition, at one concentration (the size of the read-out at that concentration, not a potency): 13.2%
The estimate for compound 3 lay 4.8 percentage points above the measured number, and the stated range covers the measured number.
By their numbers in this assay, from the lowest: compounds 2 and 3 (each within the scatter of the next); then compound 1.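

In this assay, thiophen-2-yl in place of 4-acetylphenyl gives a number 2.8 percentage points higher from compound 2 to compound 3 (within the scatter), so at this position a five-membered aromatic ring with sulfur reads no differently from the acetyl-bearing six-membered ring. Thiophen-2-yl in place of 4-formylphenyl gives a number 12.1 percentage points lower from compound 1 to compound 3 (beyond the scatter), which leaves the 4-formylphenyl group alone above the other two. Nothing measured here gives a reason for either step.

Open, as far as these compounds go, is how an amine or a carboxylic acid in place of the formyl group on the phenyl ring would read, and whether an unsubstituted phenyl ring here would group with the formyl compound or with the other two.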